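Chloro in Place of Trifluoromethyl on an Aryl Urea

A few compounds are considered here, and "the series" means these few. Any claim that something is new, unique, unknown or untested is made for them only; others in the source may bear on it.

Compound 2 `O=C(Nc1cccc(-n2cc(-c3ccncc3)c(-c3cc(O)cc(Cl)c3)n2)c1)Nc1ccc(Cl)c(C(F)(F)F)c1` sits at the lower of the two measured numbers in a functional assay on MDA-MB-231 cells (Homo sapiens) for inhibition, read by sulforhodamine B assay, with a stated time of 48 h, tested at 10 uM (on this read-out lower numbers stand for a stronger effect and higher numbers for a weaker effect at the one concentration tested), where compound 2 gives -47.3%. Compound 1 `COc1cc(Cl)cc(-c2nn(-c3cccc(NC(=O)c4ccc(Cl)c(Cl)c4)c3)cc2-c2ccncc2)c1` gives 33.9% in this assay, a gap beyond the usual scatter. Compound 3 `O=C(Nc1cccc(-n2cc(-c3ccncc3)c(-c3cc(O)cc(Cl)c3)n2)c1)Nc1ccc(Cl)c(Cl)c1` has not yet been measured; it differs from compound 2 by one change (chloro in place of trifluoromethyl on an aromatic carbon). Going by the values given here, no measured pair shows this change, so the expected step is a number 9.3 percentage points higher from compound 2 to compound 3 (within the scatter), small and within the scatter. Compound 3 is therefore estimated at -38%, with a range from -75% to 5%.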

Compound 3, a percentage reported as activity, at one concentration (the size of the read-out at that concentration, not a potency): -38.1%
Compound 3: the middle estimate sits 0.1 percentage points above what was measured, within the range that was stated.
By their numbers in this assay, from the lowest: compounds 2 and 3 (each within the scatter of the next); then compound 1.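

Replacing trifluoromethyl with chloro on the aryl urea, at the place ortho to a chloro group, gives a number 9.2 percentage points higher from compound 2 to compound 3 (within the scatter) in this assay. Going by these compounds alone, this is the first measured pair to isolate this position, and it shows that a single chlorine atom can stand in for the larger trifluoromethyl without a change beyond the scatter. Nothing available explains why the two groups read alike.

From the compounds shown here alone, whether an amine or a carboxylic acid at this position would read the same stays open. So does whether this step would hold on a different core.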